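The source may hold more compounds than are shown below. What is called first, only, known or untested is meant among the compounds shown, and "the series" means these compounds.

Three measured compounds share one core and differ only in the group carried on the chain that leads to the sulfonyl sulfur. Compound 1 `CC(C)(C)OC(=O)NCCS(=O)(=O)NC(=O)c1ccc(Nc2nc(NC3(c4ccc(Cl)cc4)CC3)nc(OCC(F)(F)F)n2)cc1` gives 92% in an ADME assay on microsomes from liver (Homo sapiens) for metabolic stability, with a stated time of 10 min; on this read-out lower numbers stand for a less stable compound and higher numbers for a more stable compound. Compound 2 `CCS(=O)(=O)NC(=O)c1ccc(Nc2nc(NC3(c4ccc(Cl)cc4)CC3)nc(OCC(F)(F)F)n2)cc1` gives 100% in this assay, and compound 3 `CC(C)(C)CNCCS(=O)(=O)NC(=O)c1ccc(Nc2nc(NC3(c4ccc(Cl)cc4)CC3)nc(OCC(F)(F)F)n2)cc1` gives 89%. Compound 3 has the lowest of the three numbers: one of its steps is a number 3 percentage points lower from compound 1 to compound 3 (within the scatter), while the other is a number 11 percentage points lower from compound 2 to compound 3 (beyond the scatter).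

Compound 4 `CC(=O)NCCS(=O)(=O)NC(=O)c1ccc(Nc2nc(NC3(c4ccc(Cl)cc4)CC3)nc(OCC(F)(F)F)n2)cc1` differs from compound 3 by acetyl in place of neopentyl on an amine nitrogen. Among the measured compounds shown here, the step that bears most directly on this is the one from compound 1 to compound 3, where neopentyl replaced tert-butoxycarbonyl on the same nitrogen and gave a number 3 percentage points lower from compound 1 to compound 3 (within the scatter). Returning from neopentyl to a carbonyl-bearing group, acetyl, is therefore expected to move the number little, if at all, in this assay. The expected step is a number 3 percentage points higher from compound 3 to compound 4 (within the scatter), and compound 4 is expected to give about 92%, most likely between 80% and 100%.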

Compound 4, percent of the compound remaining: 95%
The estimate for compound 4 lay 3 percentage points below the measured number; low and high end bracket the measured number.
By their numbers in this assay, from the lowest: compounds 3, 1, 4 and 2 (each within the scatter of the next, the first and the last beyond it).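

In this assay, acetyl in place of neopentyl on the amine nitrogen gives a number 6 percentage points higher from compound 3 to compound 4 (within the scatter) and methyl in place of tert-butoxy on the carbonyl carbon gives a number 3 percentage points higher from compound 1 to compound 4 (within the scatter), so neither change separates these compounds. Acetamido in place of hydrogen gives a number 5 percentage points lower from compound 2 to compound 4 (within the scatter), whereas neopentylamino at this place went beyond the scatter, so a group on this chain carbon need not produce a step of that size, although compound 3 and compound 4 themselves remain within the scatter of each other. Nothing shown gives a cause for these small differences.

The compounds shown leave open whether an unsubstituted amine or a carboxylic acid at this place would also stay within the scatter of compound 2. They also leave open what a longer chain carrying the acetamido group, or a benzoyl group on the same nitrogen, would do.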